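The compounds below may be only part of what the source reports. "The series", "measured", "known", "first", "only" and "open" are said of these compounds alone.

Of the compounds shown here, two sharing one core have been measured in a functional assay on A549 cells (Homo sapiens) for cytotoxicity, read by sulforhodamine B assay, with a stated time of 24 h; on this read-out higher numbers stand for weaker inhibition of growth and lower numbers for stronger inhibition of growth. Compound 1 `COc1ccc(C(=O)/C=C/c2cc3ccccc3[nH]c2=O)cc1` carries a methoxy group and gives 3210 nM. Compound 2 `O=C(/C=C/c1cc2ccccc2[nH]c1=O)c1ccc(O)cc1` carries a hydroxy group in the same place and gives 2730 nM. Within the data shown here, the only measured step, a 1.2-fold lower number from compound 1 to compound 2 (0.07 log units; within the scatter), is small, so the two numbers cannot be told apart; compound 2 simply has the lower of the two numbers, with compound 1 close by.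

Compound 3 `O=C(/C=C/c1cc2ccccc2[nH]c1=O)c1ccc(Cl)cc1` is the next member. It differs from compound 2 by chloro in place of hydroxy on an aromatic carbon. Among the measured compounds shown here, no measured step involves a chloro group, so the one step at hand, from a methyl-bearing oxygen to a bare hydroxy, bears on it only loosely: it shows that a swap at this position left this assay essentially unchanged. On that basis the expected step of a 1.4-fold lower number from compound 2 to compound 3 (0.14 log units; within the scatter) is modest, perhaps toward a somewhat lower number, but not clearly beyond the scatter. Compound 3 is therefore estimated at 2000 nM, with a likely range from 700 nM to 6000 nM.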

Compound 3, concentration for 50% growth inhibition: 7240 nM
Beside the measured number, compound 3's estimate is 3.6-fold (0.56 log units) below it; measured number above the stated range.
By their numbers in this assay, from the lowest: compounds 2 and 1 (each within the scatter of the next); then compound 3.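

Within this assay, this position proves sensitive to what sits on it: exchanging hydroxy and methoxy had left the number within the scatter, but putting chloro there gives a 2.7-fold higher number from compound 2 to compound 3 (0.42 log units; beyond the scatter) and a 2.3-fold higher number from compound 1 to compound 3 (0.35 log units; beyond the scatter) in the other comparison. Both steps are modest yet beyond the scatter, so compound 3 has the highest number of the three, which here means the weakest inhibition of growth, and the change runs in one direction from either oxygen-bearing group. Hydroxy counts one hydrogen-bond donor and one hydrogen-bond acceptor while chloro counts neither, but this is only a tally of the two groups, and no measurement shown accounts for the shift.

On these data alone, with three groups at this position, it remains open whether the higher number is particular to chloro or is shared by other groups that carry no oxygen, and a fluoro group, a methyl group or an amine in the same place would help to separate those two readings. As far as these compounds go, it is also open whether chloro would give a similar step at another place on this aromatic ring, or whether a carboxylic acid here would move the number in either direction.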